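Hydroxy to methoxy on compound 2

The compounds below may be only part of what the source reports. "The series", "measured", "known", "first", "only" and "open" are said of these compounds alone.

Going by the values given here, in a functional assay on MCF7 cells (Homo sapiens) for inhibition, read by sulforhodamine B assay, with a stated time of 48 h (on this read-out higher numbers stand for weaker inhibition of growth and lower numbers for stronger inhibition of growth), compound 2 `CC1(/C=C/c2ccccc2O)C=CC(=O)O1` gives 46200 nM, the higher of the two numbers so far, and compound 1 `CC1(/C=C/c2ccccc2C(F)(F)F)C=CC(=O)O1` gives 13500 nM. Compound 3 `COc1ccccc1/C=C/C1(C)C=CC(=O)O1` has methyl in place of hydrogen on an oxygen on an aromatic ring, hydroxy to methoxy: methyl in place of hydrogen on an oxygen on an aromatic ring. Among the compounds with values here, the only measured step bearing on this is the modest 3.4-fold higher number from compound 1 to compound 2 (0.53 log units; beyond the scatter), which introduces the hydroxy group but does not test methyl on that oxygen. A modest step towards stronger inhibition, smaller than that one, is therefore expected in this assay. The expected change is a 2.1-fold lower number from compound 2 to compound 3 (0.32 log units; beyond the scatter). For compound 3 the estimated value is 22000 nM, with an expected range of 10000 nM to 48000 nM.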

Compound 3, concentration for total growth inhibition: 27000 nM
The estimate for compound 3 lay 1.2-fold (0.09 log units) below the measured number, within the range that was stated.
By their numbers in this assay, from the lowest: compounds 1, 3 and 2 (each within the scatter of the next, the first and the last beyond it).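

Methyl on the oxygen on the aromatic ring gives a 1.7-fold lower number from compound 2 to compound 3 (0.23 log units; within the scatter) in this assay and so adds no change beyond the scatter. Methoxy in place of trifluoromethyl gives a 2.0-fold higher number from compound 1 to compound 3 (0.30 log units; within the scatter) and also stays within the scatter, so compound 3 is not separated from either neighbour, although a 3.4-fold higher number from compound 1 to compound 2 (0.53 log units; beyond the scatter) separates those two. No supporting data bear on these steps.

Open, from the compounds shown here alone, is whether a longer chain on this oxygen, as in ethoxy or benzyloxy, stays in the same range. Also open, going by these compounds, is how an amine or a carboxylic acid in place of the oxygen group would read.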